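From phenyl to (furan-2-yl)carbonyl on compound 3

The compounds below may be only part of what the source reports. "The series", "measured", "known", "first", "only" and "open" are said of these compounds alone.

In a functional assay on L5178Y cells (Mus musculus) for inhibition, read by MTT assay, with a stated time of 24 h (a higher number here means a weaker inhibitor, a lower number a stronger inhibitor), compound 3 `COc1cc(O)c2c(c1)O[C@H](c1ccc(O)cc1)C/C2=N\Nc1ccccc1` gives only a limit, >= 11300 nM. Compound 1 `Oc1ccc([C@@H]2C/C(=N\Nc3ccccc3)c3c(O)cc(O)cc3O2)cc1` also gives only a limit, >= 11300 nM. Compound 2 `Oc1ccc([C@@H]2C/C(=N\Nc3cnccn3)c3c(O)cc(O)cc3O2)cc1` again gives only a limit, >= 11300 nM. Compound 4 `COc1cc(O)c2c(c1)O[C@H](c1ccc(O)cc1)C/C2=N\NC(=O)c1ccco1` carries (furan-2-yl)carbonyl in place of phenyl on an amine nitrogen. The two measured steps, a step that the two limits leave unreadable from compound 1 to compound 2 and a step that the two limits leave unreadable from compound 1 to compound 3, have no readable size, and neither makes this change. They therefore suggest no direction. The estimated step, a step that the limit leaves unreadable from compound 3 to compound 4, is expected to stay within the scatter, and it rests only on (the limit of >= 11300 nM in this assay, at which 3 of the 3 values shown sit). Compound 4 is expected at about 14000 nM, with an estimated range from 5000 nM to 40000 nM.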

Compound 4, half-maximal inhibitory concentration: >= 11300 nM
Compound 4: a limit, no number; the forecaster's own chance of this, stated with the estimate: 70%; the middle value is on the limit's open side.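

Compound 3 and compound 4 both give only a limit in this assay, so the step between them cannot be read. The compounds shown leave open which change, if any, would yield an actual number rather than a limit: the limit of >= 11300 nM in this assay, at which 4 of the 4 values shown sit.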